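Pyrazine acylhydrazones: halogen swap and cytotoxicity on macrophage cells

The source may report more compounds than this note shows. Statements on the series, on what has been measured and on what is new or still open speak of the compounds shown alone.

Measured compounds:
compound 1 `O=C(N/N=C/c1ccccc1F)c1cnccn1` gives 100%
compound 2 `O=C(N/N=C/c1cccc(F)c1)c1cnccn1` gives 49%
compound 3 `O=C(N/N=C/c1ccccc1Br)c1cnccn1` gives 98%

All three share one amide-hydrazone core carrying a halogenated aromatic ring, and all were tested in an ADME assay on J774 cells (Mus musculus) for cytotoxicity, read by MTT assay, with a stated time of 48 h, tested at 50 ug/mL; on this read-out higher numbers stand for a weaker effect at the one concentration tested and lower numbers for a stronger effect. In this assay compound 1 gives 100%, compound 3 gives 98% and compound 2 gives 49%. Compound 2 stands lowest of the three, and both gaps to it lie beyond the scatter.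

For the measured compounds named here, the one completed step is the change (bromo in place of fluoro on an aromatic carbon), which gave a number 2 percentage points lower from compound 1 to compound 3 (within the scatter). Compound 2 has the same atoms as compound 1 joined differently; the difference between the two cores is not broken down here.

Compound 4 `O=C(N/N=C/c1cccc(Br)c1)c1cnccn1` is not yet measured. It differs from compound 2 by bromo in place of fluoro on an aromatic carbon. Going by the values given here, this is the same kind of change as the one from compound 1 to compound 3, but not the same: there the new group stands ortho to a large group, here it stands meta to a large group.

Because the step of a number 2 percentage points lower from compound 1 to compound 3 (within the scatter) lay within the scatter, a similarly small step is expected from compound 2 to compound 4, namely a number 1 percentage points higher from compound 2 to compound 4 (within the scatter). The expectation rests on that single pair only, and on the value 49% of compound 2 as the starting point. Compound 4 is accordingly estimated at 50%, with a range from 30% to 75%.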

Compound 4, a percentage reported as activity, at one concentration (the size of the read-out at that concentration, not a potency): 100%
The estimate for compound 4 lay 50 percentage points below the measured number, outside the stated range (above it).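

In this assay, bromo in place of fluoro on an aromatic carbon gave a number 51 percentage points higher from compound 2 to compound 4 (beyond the scatter), so on these two cores the same change did not give a step of the same size: the same change on two cores in this assay, a number 2 percentage points lower (within the scatter) from compound 1 to compound 3 and a number 51 percentage points higher (beyond the scatter) from compound 2 to compound 4, 53 percentage points apart, beyond the scatter of two such steps

For the compounds shown here, for this series, the step on the core of compound 1 is therefore no guide to the step where the group stands meta to a large group, and the weaker effect of bromo there holds for this one pair only. Two pairs at a single concentration do not show why the steps differ, whether the location of the halogen on the aromatic ring accounts for the gap, or how the change would behave on any further core.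

On these data alone, it remains open whether the stronger effect seen for compound 2, at 49%, is particular to fluoro meta to a large group or would also appear with another group in that place, such as chloro, methoxy, an amine or a carboxylic acid. Also open, as far as these compounds go, is whether the gap between the two steps would persist at other concentrations, where a full concentration-response reading could replace the single-point figures in this assay.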